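A few compounds are considered here, and "the series" means these few. Any claim that something is new, unique, unknown or untested is made for them only; others in the source may bear on it.

In an ADME assay on HepG2 cells (Homo sapiens) for cytotoxicity, read by sulforhodamine B assay, with a stated time of 48 h (on this read-out higher numbers stand for lower toxicity in this test and lower numbers for higher toxicity in this test), every measured compound reached only a limit of the assay:

Compound 1 `COc1nc2ccccc2cc1/C=C/c1noc(-c2ccccc2)n1` gives > 240000 nM, a limit.
Compound 2 `COc1nc2ccccc2cc1/C=C/c1noc(-c2ccc(F)cc2)n1` gives > 230000 nM, a limit.
Compound 3 `COc1cccc(-c2nc(/C=C/c3cc4ccccc4nc3OC)no2)c1` gives > 220000 nM, a limit.

Compound 3 thus stands where the other two stand: at a limit of this assay, with no number resolved. The change to compound 4 `COc1nc2ccccc2cc1/C=C/c1noc(COc2ccccc2)n1` is phenoxymethyl in place of 3-methoxyphenyl on an aromatic carbon. Going by the values given here, three measured steps bear on it: a step that the two limits leave unreadable from compound 1 to compound 2, a step that the two limits leave unreadable from compound 1 to compound 3 and a step that the two limits leave unreadable from compound 2 to compound 3, none readable in size, their ends resting at the limit of > 240000 nM in this assay, at which 1 of the 3 values shown sits, the limit of > 230000 nM in this assay, at which 1 of the 3 values shown sits, or (the limit of > 220000 nM in this assay, at which 1 of the 3 values shown sits). No step beyond the scatter is therefore expected for compound 4, and the estimated step of a number no higher from compound 3 to compound 4 (the limit leaves the size open) rests on those three limits alone. Compound 4 is expected to give 220000 nM, between 100000 nM and 400000 nM, most likely again as a limit.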

Compound 4, half-maximal cytotoxic concentration: > 220000 nM
Compound 4: only a limit was reported; the forecaster's own chance of this, stated with the estimate: 85%; the middle value sits exactly at the limit.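

Going by these compounds alone, compound 4, like compound 1, compound 2 and compound 3, reached only a limit in this assay, so no step between these compounds can be read. The compounds shown leave open whether any of these groups on the shared core changes the read-out at all.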